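The compounds below may be only part of what the source reports. "The series", "measured", "known", "first", "only" and "open" are said of these compounds alone.

Measured compounds:
compound 1, `FC(F)(F)c1cccc(-c2nc3cnc(Nc4ccncn4)cc3[nH]2)c1`, 200000 nM
compound 2, `Fc1ccc(-c2nc3cnc(Nc4ccc(C(F)(F)F)cn4)cc3[nH]2)cc1F`, 6000 nM

In a physicochemical assay for solubility, using the shake flask method, measured as kinetic solubility, with a stated time of 20 h, at pH 2 (a higher number here means a more soluble compound, a lower number a less soluble compound), compound 1 gives 200000 nM. In this assay compound 2 gives 6000 nM, the lowest of the two numbers; its nearest neighbour is compound 1, whose number is higher by a margin that lies beyond the usual scatter. Among the compounds with values here, no pair of measured compounds differs in only one place, so no single step has been measured; the two values show only that compound 2 sits clearly under compound 1.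

Compound 3 `FC1(F)CCC(c2nc3cnc(Nc4ccc(C(F)(F)F)cn4)cc3[nH]2)CC1` has not been measured. It differs from compound 2 in one place: 4,4-difluorocyclohexyl in place of 3,4-difluorophenyl on an aromatic carbon. Nothing measured in the series covers a change of this kind, so the expectation rests on the change itself and on the standing of compound 2. The expected step is an increase in this assay, modest but beyond the scatter: a 3.3-fold higher number from compound 2 to compound 3 (0.52 log units; beyond the scatter) is the step expected. For compound 3 the estimate in this assay is 20000 nM, with a range from 5000 nM to 80000 nM.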

Compound 3, solubility: 199000 nM
The estimate for compound 3 lay 10-fold (1.00 log units) below the measured number; the whole stated range lies below it.
By their numbers in this assay, from the lowest: compound 2; then compounds 3 and 1 (each within the scatter of the next).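

In this assay, within the data shown here, the replacement of 3,4-difluorophenyl by 4,4-difluorocyclohexyl, on an aromatic carbon between two ring nitrogen atoms, gives the first single-place step, and a large one: a 33-fold higher number from compound 2 to compound 3 (1.52 log units; beyond the scatter). The two groups match in every count printed for them, with the same heavy atoms, the same carbon and fluorine content and no hydrogen-bond donors or acceptors, and they differ in that one ring is aromatic and the other is not; a change of ring type at this position, with composition held, is therefore enough for a step well beyond the scatter. No measurement at hand bears on what lies behind this step.

Going by these compounds, this remains a single pair, so it is open whether the same replacement would move the number as far on the rest of the structure of compound 1. Also open, on these data alone, is whether the fluorine atoms matter to the step, which plain cyclohexyl would test, and how a ring bearing an amine or a hydroxyl group, or an open alkyl chain, would read at the same place.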